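Swapping cyclopropyl for pyrrolidinyl on the aryl ring

The compounds below may be only part of what the source reports. "The series", "measured", "known", "first", "only" and "open" are said of these compounds alone.

Measured compounds:
compound 1, `CN1CCN(CCCS(=O)(=O)c2ccc3nc(NC(=O)NC(=O)c4cccc(-n5cccn5)c4Cl)sc3c2)CC1`: 8.8 nM
compound 2, `CCc1ccc(Cl)c(C(=O)NC(=O)Nc2nc3ccc(S(=O)(=O)CCCN4CCN(C)CC4)cc3s2)c1`: 0.078 nM
compound 3, `CN1CCN(CCCS(=O)(=O)c2ccc3nc(NC(=O)NC(=O)c4cc(C5CC5)ccc4Cl)sc3c2)CC1`: 0.33 nM

All three share one core and differ only in the aryl group attached to the carbonyl. In an assay on HEK293 cells for displacement of a labelled ligand from growth hormone secretagogue receptor type 1 (Homo sapiens), with a stated time of 60 min (a lower number here means a stronger inhibitor, a higher number a weaker inhibitor), compound 1 gives 8.8 nM, compound 2 gives 0.078 nM and compound 3 gives 0.33 nM. Compound 3 thus stands second highest of the three: compound 2 lies a 4.2-fold higher number from compound 2 to compound 3 (0.63 log units; beyond the scatter), while compound 1 lies far weaker, as a 27-fold lower number from compound 1 to compound 3 (1.43 log units; beyond the scatter) shows.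

Compound 4, `CN1CCN(CCCS(=O)(=O)c2ccc3nc(NC(=O)NC(=O)c4cc(N5CCCC5)ccc4Cl)sc3c2)CC1`, takes the next step: pyrrolidin-1-yl in place of cyclopropyl on an aromatic carbon. For the measured compounds named here, two measured steps bear on this. The change a 4.2-fold higher number from compound 2 to compound 3 (0.63 log units; beyond the scatter) shows that a small ring in place of an ethyl chain on this aromatic carbon costs a modest amount. The change a 27-fold lower number from compound 1 to compound 3 (1.43 log units; beyond the scatter) shows that a nitrogen-containing ring elsewhere on the aryl group, compared with cyclopropyl here, costs far more. Going by the values given here, no measured pair places a pyrrolidinyl at this exact spot, so the outcome is uncertain; a modest weakening beyond the scatter is expected, with a 3.6-fold higher number from compound 3 to compound 4 (0.56 log units; beyond the scatter). Compound 4 is therefore estimated at 1.2 nM, within 0.25 nM to 6 nM.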

Compound 4, half-maximal inhibitory concentration: 0.29 nM
Compound 4: the middle estimate sits 4.1-fold (0.62 log units) above what was measured; the measured number falls inside the stated range.
By their numbers in this assay, from the lowest: compound 2; then compounds 4 and 3 (each within the scatter of the next); then compound 1.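

In this assay, this aromatic carbon takes pyrrolidin-1-yl as readily as cyclopropyl, with a 1.1-fold lower number from compound 3 to compound 4 (0.06 log units; within the scatter) leaving the two compounds indistinguishable even though the entering ring is larger and carries a nitrogen and a hydrogen-bond acceptor. Ethyl keeps its lead over this new ring too, as a 3.7-fold higher number from compound 2 to compound 4 (0.57 log units; beyond the scatter) shows, while a 30-fold lower number from compound 1 to compound 4 (1.48 log units; beyond the scatter) places the 2-chloro-3-(1H-pyrazol-1-yl)phenyl compound far from this one, so a nitrogen-bearing ring does not by itself carry a cost in this series. No supporting evidence is available to explain why the two rings match here.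

On these data alone, whether this tolerance extends to a piperidin-1-yl or morpholin-4-yl ring, or to an open-chain dimethylamino group, remains open. So does whether a propyl chain at this carbon would keep the lead seen with ethyl.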